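This account rests on a few compounds, and the source may have more. Where it says the series, first, only, none or still open, it means among the compounds named here.

Measured so far:
compound 1 `CN(C)C(=O)c1cc2cnc(Nc3ccc(S(=O)(=O)NCCCCCN=C=S)cc3)nc2n1C1CCCC1` — 56.6%
compound 2 `CN(C)C(=O)c1cc2cnc(Nc3ccc(S(=O)(=O)NCCCCCCCN=C=S)cc3)nc2n1C1CCCC1` — 32.6%

In a functional assay on A549 cells (Homo sapiens) for inhibition, read by CCK-8 assay, with a stated time of 72 h, tested at 1 uM (on this read-out higher numbers stand for a stronger effect at the one concentration tested and lower numbers for a weaker effect), compound 1 stands highest of the two numbers; its nearest neighbour is compound 2, and the step of a number 24 percentage points lower from compound 1 to compound 2 (beyond the scatter) is beyond the scatter. Compound 3 `CN(C)C(=O)c1cc2cnc(Nc3ccc(NC(=O)CCCCN=C=S)cc3)nc2n1C1CCCC1` is not yet measured in this assay. It differs from compound 1 as a group of 10 heavy atoms (6 carbon, 2 nitrogen, 1 oxygen, 1 sulfur; no ring) in place of a group of 12 heavy atoms (6 carbon, 2 nitrogen, 2 oxygen, 2 sulfur; no ring), on an aromatic carbon; the sulfonamide of compound 1 gives way to an amide, and the chain carrying the isothiocyanate is shorter. For the measured compounds named here, the only measured step, a number 24 percentage points lower from compound 1 to compound 2 (beyond the scatter), concerns a longer chain on the sulfonamide side and lowered the read-out; no step covers a sulfonamide-to-amide exchange. The expected step of a number 6.6 percentage points lower from compound 1 to compound 3 (within the scatter) is therefore small, with wide uncertainty. Compound 3 is estimated at 50%, ranging from 25% to 75%.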

Compound 3, a percentage reported as inhibition, at one concentration (the size of the read-out at that concentration, not a potency): 38.2%
The estimate for compound 3 lay 11.8 percentage points above the measured number; low and high end bracket the measured number.
By their numbers in this assay, from the lowest: compounds 2 and 3 (each within the scatter of the next); then compound 1.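

Exchanging the sulfonamide of compound 1 for an amide and shortening the chain that carries the isothiocyanate gives, in this assay, a number 18.4 percentage points lower from compound 1 to compound 3 (beyond the scatter), so the read-out responds to a change at the link on the aromatic carbon and not only to lengthening the chain on the sulfonamide. Both changes sit in this one step and cannot be separated, and compound 1 remains the highest of the three, with neither change away from it raising the read-out. No measurement on hand explains the lower number.

An amide carrying the chain of compound 1, or a sulfonamide with a shorter chain, would show how much of the step belongs to each change. From the compounds shown here alone, a urea as the link, or an amine in place of the isothiocyanate, remains open.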